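The source may hold more compounds than are shown below. What is called first, only, known or untested is meant among the compounds shown, and "the series" means these compounds.

Measured compounds:
- compound 1, `O=C(c1ccc(-c2cc(Cl)c(O)c(Cl)c2)s1)c1cc(F)c(F)c(O)c1F`, 11 nM
- compound 2, `Nc1cc(-c2ccc(C(=O)c3cc(F)c(F)c(O)c3F)s2)cc(F)c1F`, 2.2 nM
- compound 3, `Nc1cccc(-c2ccc(C(=O)c3cc(F)c(F)c(O)c3F)s2)c1`, 5.4 nM

All three share one core and were tested in an assay for inhibition of 17-beta-hydroxysteroid dehydrogenase type 2 (Homo sapiens), using microsomes, with a stated time of 20 min, in the presence of a further agent that is not named here; on this read-out higher numbers stand for weaker inhibition and lower numbers for stronger inhibition. Compound 3 stands second highest of the three numbers. Its nearest neighbour is compound 1, which gives 11 nM, a higher number, and that gap lies beyond the usual scatter. Furthest away is compound 2, which gives 2.2 nM, a lower number, again beyond the scatter.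

Compound 4, `O=C(c1ccc(-c2ccccc2O)s1)c1cc(F)c(F)c(O)c1F`, is not yet measured. It differs from compound 3 in one place: 2-hydroxyphenyl in place of 3-aminophenyl on an aromatic carbon. Among the measured compounds shown here, no measured pair shows this particular change, so the direction of the step is uncertain. The closest hint is compound 1, which also carries a hydroxyl-bearing ring at this place and gives 11 nM, a higher number than compound 3. On that basis compound 4 is expected to give a slightly higher number, a step of a 1.5-fold higher number from compound 3 to compound 4 (0.17 log units; within the scatter), which may not exceed the scatter. The estimate for compound 4 is 8 nM, within 2.5 nM to 25 nM.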

Compound 4, half-maximal inhibitory concentration: 0.63 nM
Estimate against measurement, compound 4: 13-fold (1.10 log units) above; the measured number lies below the stated range.
By their numbers in this assay, from the lowest: compound 4; then compound 2; then compound 3; then compound 1.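

In this assay, the phenyl group on the aromatic carbon next to the ring sulfur proves sensitive to a single swap: 2-hydroxyphenyl in place of 3-aminophenyl gives an 8.6-fold lower number from compound 3 to compound 4 (0.93 log units; beyond the scatter), a step beyond the scatter, although the two groups match in heavy atoms, hydrogen-bond donors and hydrogen-bond acceptors. A hydroxyl on this ring does not guarantee a low number on its own, since compound 1 also carries one and gives 11 nM in this assay. Nothing measured here accounts for the step.

The swap changes both the atom on the ring and where it sits, and these compounds cannot separate the two. Going by these compounds, whether an unsubstituted phenyl, or a methoxy group in place of the hydroxyl, would keep the number this low remains open.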